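Removing a Phenyl Group: From Compound 2 to Compound 4

This account rests on a few compounds, and the source may have more. Where it says the series, first, only, none or still open, it means among the compounds named here.

Compound 1 `Nc1cc(C2CCNCCc3cccc(c3)OCc3cccc(c3)Cn3cc2cn3)c2nn[nH]c2n1`: 17 nM
Compound 2 `Nc1cc(Cc2ccn(Cc3cccc(-c4ccccc4)c3)n2)c2nn[nH]c2n1`: 55 nM
Compound 3 `Nc1cc(C2CCNC3CCC(CC3)COc3cccc(c3)Cn3cc2cn3)c2nn[nH]c2n1`: 31 nM

In an assay on isolated protein for inhibition of Myeloperoxidase (Homo sapiens), with a stated time of 10 min (a higher number here means a weaker inhibitor, a lower number a stronger inhibitor), compound 2 stands at the highest of the three numbers. Compound 3 lies within the usual scatter of compound 2, so the two cannot be ordered, whereas compound 1 gives a lower number that lies beyond the scatter. Compound 4 `Nc1cc(Cc2ccn(Cc3ccccc3)n2)c2nn[nH]c2n1` differs from compound 2 in one place: hydrogen in place of phenyl on an aromatic carbon. No measured pair among these compounds shows a step of this kind, so nothing measured sets its size or direction. Compound 4 is nonetheless expected to give a higher number than compound 2, by a step of a 2.7-fold higher number from compound 2 to compound 4 (0.44 log units; beyond the scatter), somewhat beyond the scatter. For compound 4 in this assay the estimate is 150 nM, expected to fall between 50 nM and 500 nM.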

Compound 4, half-maximal inhibitory concentration: 120 nM
For compound 4 the middle estimate is 1.3-fold (0.10 log units) above the measured one, within the range that was stated.
By their numbers in this assay, from the lowest: compounds 1, 3 and 2 (each within the scatter of the next, the first and the last beyond it); then compound 4.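

In this assay, within the data shown here, the change has a measured size for the first time: replacing phenyl with hydrogen on this aromatic carbon gives a 2.2-fold higher number from compound 2 to compound 4 (0.34 log units; beyond the scatter) and is a modest step beyond the scatter. The phenyl group is therefore not required for inhibition, since compound 4 still reads 120 nM without it. Nothing available explains the size of this step.

Only phenyl and hydrogen are shown at this place, so a single pair sets the whole picture. Going by these compounds, how an amine, a carboxylic acid or a longer chain on the same carbon would compare with either remains open.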